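This account rests on a few compounds, and the source may have more. Where it says the series, first, only, none or still open, it means among the compounds named here.

Measured so far:
compound 1 `CCCCCCCCC[C@]1(CO)NC[C@@H](O)[C@@H]1O` — 2.5%
compound 2 `OC[C@@]1(c2cccc(F)c2)NC[C@@H](O)[C@@H]1O` — 0%

In an assay on isolated protein for inhibition of alpha-galactosidase (Coffea arabica), tested at 1000 uM (a higher number here means more inhibition at the concentration tested (going by the name of the read-out), a lower number less inhibition), compound 1 gives 2.5% and compound 2 gives 0%. For the measured compounds named here, compound 2 holds the lower of the two numbers, but its only neighbour, compound 1, sits within the usual scatter of it, so the two values show no ordering; both lie at the floor of the read-out. Going by the values given here, no step between two measured compounds that differ in one place is available, so the size of a single change is unknown here.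

Compound 3 `COc1cccc([C@]2(CO)NC[C@@H](O)[C@@H]2O)c1` follows from compound 2 by methoxy in place of fluoro on an aromatic carbon. With both measured compounds at the floor, nothing indicates a change beyond the scatter; the expected step is a number 2 percentage points higher from compound 2 to compound 3 (within the scatter), essentially none. Compound 3 is therefore estimated at 2%, with a range from 0% to 12%.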

Compound 3, a percentage reported as inhibition, at one concentration (the size of the read-out at that concentration, not a potency): 1.6%
For compound 3 the middle estimate is 0.4 percentage points above the measured one, and the stated range covers the measured number.
By their numbers in this assay, from the lowest: compounds 2, 3 and 1 (each within the scatter of the next).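

Methoxy in place of fluoro on an aromatic carbon amounts in this assay to a number 1.6 percentage points higher from compound 2 to compound 3 (within the scatter), the first step in the series between compounds that differ in one place. At this position on the six-membered aromatic ring of carbon only, the exchange of one heavy atom for two, with one hydrogen-bond acceptor entering, gives no change that can be told from the scatter, and both compounds stay at the floor of the read-out. No supporting measurement bears on this result.

Still open, from the compounds shown here alone, is whether an amine or a carboxylic acid at this place on the ring would lift the number off the floor. Also open, going by these compounds, is whether a longer chain on the aromatic ring would do so, as a single change from compound 2 or compound 3.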